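Methoxy in place of hydrogen on the benzoyl ring

A few compounds are considered here, and "the series" means these few. Any claim that something is new, unique, unknown or untested is made for them only; others in the source may bear on it.

Measured so far:
Compound 1 `COc1cc(-c2nnc3n2NC(c2cccs2)C(C(=O)c2ccccc2)S3)cc(OC)c1OC` — > 100000 nM
Compound 2 `COc1cc(C(=O)C2Sc3nnc(-c4cc(OC)c(OC)c(OC)c4)n3NC2c2cccs2)cc(OC)c1OC` — 71000 nM
Compound 3 `COc1cc(-c2nnc3n2NC(c2ccco2)C(C(=O)c2ccccc2)S3)cc(OC)c1OC` — 39800 nM

Of the compounds shown here, three sharing one core have been tested in a functional assay on MCF7 cells (Homo sapiens) for cytotoxicity, read by MTT assay, with a stated time of 48 h; a higher number here means a weaker inhibitor, a lower number a stronger inhibitor. Compound 1 gives only a limit here, (the limit of > 100000 nM in this assay, at which 1 of the 3 values shown sits), and not a number. Compound 2 gives 71000 nM. Compound 3 gives 39800 nM, the lowest of the two numbers, though compound 2 sits within the scatter of it. The step of an at least 2.5-fold lower number from compound 1 to compound 3 (0.40 log units; beyond the scatter) is beyond the scatter; the step of an at least 1.4-fold lower number from compound 1 to compound 2 (0.14 log units; that floor lies within the scatter) has a floor that lies within it.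

The next compound, compound 4 `COc1cccc(C(=O)C2Sc3nnc(-c4cc(OC)c(OC)c(OC)c4)n3NC2c2ccco2)c1`, is not yet measured. It differs from compound 3 as methoxy in place of hydrogen on an aromatic carbon. For the measured compounds named here, the only measured step that bears on this position is an at least 1.4-fold lower number from compound 1 to compound 2 (0.14 log units; that floor lies within the scatter), which put three methoxy groups onto the same ring and gave at most a small change. A single methoxy in place of hydrogen is a smaller change still, so no step beyond the scatter is expected, with a slight lean toward a lower number. Compound 4 is therefore expected to give about 30000 nM, between 10000 nM and 90000 nM, which means an expected step of a 1.3-fold lower number from compound 3 to compound 4 (0.12 log units; within the scatter).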

Compound 4, half-maximal inhibitory concentration: > 100000 nM
Compound 4 ended at the assay's limit; the forecaster's own chance of this, stated with the estimate: 15%; middle value at least 3.3-fold (0.52 log units) from the limit.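

In this assay, the change from benzoyl to (3-methoxyphenyl)carbonyl on the furan-2-yl compound gave an at least 2.5-fold higher number from compound 3 to compound 4 (0.40 log units; beyond the scatter), so this ring can respond to a single methoxy in the direction of a weaker inhibitor, which the earlier step on the thiophen-2-yl compounds, an at least 1.4-fold lower number from compound 1 to compound 2 (0.14 log units; that floor lies within the scatter), could not establish. As far as these compounds go, compound 4 gives > 100000 nM, which is a limit of the assay and not a number, so only the floor of this step is known and its true size remains unknown. Any further comparison among the compounds shown is bounded by this limit: the limit of > 100000 nM in this assay, at which 2 of the 4 values shown sit.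

The compounds shown leave open whether the loss belongs to methoxy itself or would follow any group on this aromatic carbon, such as a hydroxyl, a fluorine or an amine. They also leave open whether the same single methoxy would act alike with thiophen-2-yl in place of furan-2-yl on the saturated ring carbon.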